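Chain Terminus Unsaturation in a Butylated Allylphenol Series

The source may report more compounds than this note shows. Statements on the series, on what has been measured and on what is new or still open speak of the compounds shown alone.

Measured so far:
Compound 1, `C=CCc1cc(C(C)=O)c(O)cc1OCCCC`: 32%
Compound 2, `C=CCc1cc(C(C)=O)c(O)cc1OCCCCCC`: 50%

Compound 2 gives the higher of the two numbers in an assay on isolated protein for inhibition of leukotriene B4 receptor 1 (Homo sapiens), tested at 10 uM; on this read-out lower numbers stand for less inhibition and higher numbers for more inhibition at the one concentration tested (going by the name of the read-out); its nearest neighbour is compound 1, reached by a number 18 percentage points higher from compound 1 to compound 2 (beyond the scatter), a modest rise beyond the scatter. Compound 3, `C=CCCCCOc1cc(O)c(C(C)=O)cc1CC=C`, has not yet been measured in this assay. It differs from compound 2 by vinyl in place of ethyl on a saturated chain carbon, four bonds along the chain from an oxygen on an aromatic ring. For the measured compounds named here, the only measured step, the one between compound 1 and compound 2, concerns the length of the chain four bonds along from the aromatic oxygen; the present change keeps that length and alters only the saturation of its outer end. Going by the values given here, no measured pair speaks to that, so the account expects little movement: an estimated step of a number 2 percentage points lower from compound 2 to compound 3 (within the scatter), within the scatter. Compound 3 is therefore estimated at 48% in this assay, with a range from 30% to 66%.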

Compound 3, a percentage reported as inhibition, at one concentration (the size of the read-out at that concentration, not a potency): 73%
Beside the measured number, compound 3's estimate is 25 percentage points below it, and the stated range ends below it.
By their numbers in this assay, from the lowest: compound 1; then compound 2; then compound 3.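

In this assay, the outer end of the chain proves to count as well as its length: with the length kept, vinyl in place of ethyl gives a number 23 percentage points higher from compound 2 to compound 3 (beyond the scatter). Set against hydrogen at the same place, vinyl gives a number 41 percentage points higher from compound 1 to compound 3 (beyond the scatter), so both ethyl and vinyl raise the number at this position, and vinyl raises it further. Nothing available here accounts for what the double bond contributes.

The compounds shown leave open whether the rise depends on the double bond standing at the very end of the chain, or would carry over to a terminal alkyne or to a longer chain ending in the same vinyl group. They also leave open how a carboxylic acid or an amine at that outer end would read.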